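The compounds below may be only part of what the source reports. "The series", "measured", "known", "first", "only" and "open" are said of these compounds alone.

Measured so far:
compound 1, `CCCC(Oc1ccc2c(c1)c(SC(C)(C)C)c(CC(C)(C)C(=O)O)n2Cc1ccc(Cl)cc1)c1ccc2ccccc2n1` — > 52 nM
compound 2, `Cc1nc2ccc(COc3ccc4c(c3)c(SC(C)(C)C)c(CC(C)(C)C(=O)O)n4Cc3ccc(Cl)cc3)cc2s1` — 6 nM

Compound 1 gives > 52 nM in a functional assay for inhibition, with Homo sapiens as the target (a lower number here means a stronger inhibitor, a higher number a weaker inhibitor), and this value is a limit of the assay, not a number. Within the data shown here, compound 2 gives 6 nM in this assay, and it is the only number. Among the measured compounds shown here, the one other value shown, that of compound 1, is a limit of the assay: the limit of > 52 nM in this assay, at which 1 of the 2 values shown sits. For the measured compounds named here, no step between two measured compounds is available, so nothing here tells how a change at the chain carbon bound to the ring oxygen moves the read-out.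

Compound 3, `CC(C)c1csc(COc2ccc3c(c2)c(SC(C)(C)C)c(CC(C)(C)C(=O)O)n3Cc2ccc(Cl)cc2)n1`, differs from compound 2 in one place: 4-isopropyl-1,3-thiazol-2-yl in place of 2-methyl-1,3-benzothiazol-6-yl on a saturated chain carbon bound to an oxygen on an aromatic ring.

Going by the values given here, with no measured step to lean on, a step of modest size is expected from compound 2 to compound 3, a 2.3-fold higher number from compound 2 to compound 3 (0.37 log units; beyond the scatter), tending toward weaker inhibition but possibly staying within the scatter. Compound 3 is therefore estimated at 14 nM in this assay, with a range from 4 nM to 50 nM.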

Compound 3, half-maximal inhibitory concentration: 3 nM
Estimate against measurement, compound 3: 4.7-fold (0.67 log units) above; the whole stated range lies above it.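

In this assay, the exchange on a saturated chain carbon bound to an oxygen on an aromatic ring gives no difference that can be read (a 2.0-fold lower number from compound 2 to compound 3 (0.30 log units; within the scatter)). Among these compounds, this is the first measured step at this position, and it shows that 2-methyl-1,3-benzothiazol-6-yl and 4-isopropyl-1,3-thiazol-2-yl cannot be told apart here, even though the entering group has a single five-membered aromatic ring and lacks the six-membered aromatic ring of carbon only. Nothing measured here gives a reason for this equivalence.

The value of compound 1 (> 52 nM) is a limit of the assay, not a number. Still open, from the compounds shown here alone, is how this assay responds to a phenyl ring, a morpholine or a carboxylic acid in place of 4-isopropyl-1,3-thiazol-2-yl.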